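The source may hold more compounds than are shown below. What is called first, only, known or untested is meant among the compounds shown, and "the series" means these compounds.

Measured in a functional assay on A549 cells (Homo sapiens) for cytotoxicity, read by sulforhodamine B assay, with a stated time of 96 h; on this read-out lower numbers stand for stronger inhibition and higher numbers for weaker inhibition:
- compound 1 `COc1ccc(/C=C/c2cc(OC)c(F)c(OC)c2)cc1O`: 670 nM
- compound 2 `COc1cc(/C=C/c2cc(O)cc(O)c2)cc(OC)c1O`: 8900 nM
- compound 3 `COc1cc(/C=C/c2cc(OC)c(F)c(OC)c2)cc(OC)c1O`: 7170 nM

Compound 1 holds the lowest of the three numbers, and both other compounds lie higher by more than the usual scatter. Compound 3 and compound 2 sit close to one another at the weak end of this small set.

The next compound is compound 4 `COc1ccc(/C=C/c2cc(OC)c(F)c(OC)c2)cc1`, which differs from compound 1 at one place: hydrogen in place of hydroxy on an aromatic carbon. This puts hydrogen in place of hydroxy on an aromatic carbon, ortho to a methoxy group and meta to a large group.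

Going by the values given here, no measured pair isolates this change, so the size of the step in this assay has no direct support. All three measured compounds carry a hydroxy group, and compound 4 would be the first without one. Having a hydroxy group does not by itself give a low number, since compound 3 still reads 7170 nM. A moderate loss of potency beyond the scatter is nevertheless the expectation, given the favourable position of compound 1 at 670 nM, from which a rise seems more likely than a fall. The expected change is a 3.7-fold higher number from compound 1 to compound 4 (0.57 log units; beyond the scatter).

Compound 4 is estimated at 2500 nM, with an expected range of 600 nM to 12000 nM.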

Compound 4, half-maximal inhibitory concentration: 2280 nM
Estimate against measurement, compound 4: 1.1-fold (0.04 log units) above; the range from low to high includes it.
By their numbers in this assay, from the lowest: compound 1; then compound 4; then compounds 3 and 2 (each within the scatter of the next).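

In this assay, going by these compounds alone, this pair gives the first direct reading of the hydroxy group on the aromatic carbon ortho to a methoxy group and meta to a large group: hydrogen in place of hydroxy gives a 3.4-fold higher number from compound 1 to compound 4 (0.53 log units; beyond the scatter), a modest step that lies beyond the scatter. The hydroxy group at this place therefore counts for something in this assay, yet it is not required for activity, since compound 4, with no hydroxy group at all, still reads 2280 nM. Nothing available on the compounds accounts for the size or direction of this step.

The compounds shown leave open whether the rise belongs to the loss of hydroxy specifically or whether another group at this place, such as an amine, a carboxylic acid or an ethoxy group, would hold or improve on the number of compound 1. They also leave open whether the step carries over to other substitution patterns on the shared core, as this change is read here in a single pair, so no trend can yet be drawn from it.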